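Halogen swap on the anilino ring: notes on four thioacetamides

The source may hold more compounds than are shown below. What is called first, only, known or untested is meant among the compounds shown, and "the series" means these compounds.

Measured compounds:
- compound 1, `O=C(CSc1nc(Nc2ccccc2)c2ccccc2n1)Nc1ccc(F)cc1`: 34100 nM
- compound 2, `O=C(CSc1nc(Nc2ccccc2)c2ccccc2n1)Nc1ccc(Cl)cc1`: 17200 nM
- compound 3, `C=CC(=O)Nc1cccc(NC(=O)CSc2nc(Nc3ccccc3F)c3ccccc3n2)c1`: 18700 nM

In a functional assay on MDA-MB-231 cells (Homo sapiens) for inhibition, read by MTT assay, with a stated time of 72 h (on this read-out lower numbers stand for stronger inhibition and higher numbers for weaker inhibition), compound 1 gives 34100 nM, and in the same assay compound 2 gives 17200 nM. Among the compounds with values here, the single change between them is chloro in place of fluoro on an aromatic carbon, and it yields a 2.0-fold lower number from compound 1 to compound 2 (0.30 log units; within the scatter), so the two values are not separable here. Compound 3 carries a different core; in this assay compound 3 gives 18700 nM, a number within the scatter of both compound 1 and compound 2. The difference between the core of compound 3 and the core of compound 1 is not broken down here.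

Compound 4, `C=CC(=O)Nc1cccc(NC(=O)CSc2nc(Nc3ccccc3Cl)c3ccccc3n2)c1`, is not yet measured. It differs from compound 3 by chloro in place of fluoro on an aromatic carbon. Within the data shown here, this is the same kind of change as the one from compound 1 to compound 2, not the same change: in compound 1 and compound 2 the place is para to a large group, whereas in compound 3 and compound 4 it is ortho to a large group.

Compound 4 is expected to show a 1.6-fold lower number from compound 3 to compound 4 (0.19 log units; within the scatter), set beside the measured 2.0-fold lower number from compound 1 to compound 2 (0.30 log units; within the scatter). This expectation rests on compound 1 and compound 2, because a 2.0-fold lower number from compound 1 to compound 2 (0.30 log units; within the scatter) lies within the scatter, and the core of compound 3 is not probed by any other pair. For compound 4 the estimate is 12000 nM. The lower end of that estimate for compound 4 is 5000 nM. The upper end of that estimate for compound 4 is expected to be 30000 nM.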

Compound 4, half-maximal inhibitory concentration: 12700 nM
Beside the measured number, compound 4's estimate is 1.1-fold (0.02 log units) below it; measured number inside the range.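

In this assay, chloro in place of fluoro at the place ortho to a large group gives a 1.5-fold lower number from compound 3 to compound 4 (0.17 log units; within the scatter), so compound 3 and compound 4 are not separable on this read-out. Set beside the earlier step, the change shows no detectable difference in size between the two cores, and on this evidence it carries from one to the other without any visible shift: the same change on two cores in this assay, a 2.0-fold lower number (0.30 log units; within the scatter) from compound 1 to compound 2 and a 1.5-fold lower number (0.17 log units; within the scatter) from compound 3 to compound 4, 1.3-fold (0.13 log units) apart, within the scatter of two such steps. This agreement is between two small steps, neither clear of the scatter, so it does not show that chloro lowers the number on either core, and the two pairs also differ in the place of the halogen, which cannot be separated from the difference in core here.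

Still open, from the compounds shown here alone, is whether any group at this place moves the number beyond the scatter on the core of compound 3, for example bromo, methoxy or trifluoromethyl, or a more distant kind of group such as an amine or a carboxylic acid. Also open, going by these compounds, is whether such a group would give the same step on the core of compound 1, which is the test of transfer that two halogens alone cannot provide.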